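Swapping the ketone arm of compound 1 for an ester

A few compounds are considered here, and "the series" means these few. Any claim that something is new, unique, unknown or untested is made for them only; others in the source may bear on it.

Measured so far:
compound 1, `N#C/C(=C\c1c(-c2ccccc2)[nH]c2ccccc12)C(=O)c1cccs1`: 28000 nM
compound 2, `COc1ccc(-c2[nH]c3ccc(OC)cc3c2/C=C(\C#N)S(=O)(=O)c2ccccc2)cc1`: > 100000 nM
compound 3, `CC(=O)/C(=C/c1c(-c2ccccc2)[nH]c2ccccc12)C(=O)c1ccccc1`: > 100000 nM

Of the compounds shown here, three have been tested in a functional assay on SK-MEL-28 cells (Homo sapiens) for cytotoxicity, read by MTT assay, with a stated time of 96 h; a higher number here means that more compound is needed for the effect, a lower number that less compound is needed. Compound 1 is the only one of them that gives a number at all, with 28000 nM. Compound 2 reaches only a limit of the assay, > 100000 nM. Compound 3 likewise stops at a limit, > 100000 nM. Among the measured compounds shown here, both of these sit at the limit of > 100000 nM in this assay, at which 2 of the 3 values shown sit, so no step between measured compounds can be read from these data.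

Compound 4, `COCCOC(=O)/C(C#N)=C/c1c(-c2ccccc2)[nH]c2ccccc12`, shares its core with compound 1 and differs from it in one place: 2-methoxyethoxy in place of thiophen-2-yl on a carbonyl carbon. For the measured compounds named here, no measured pair shows this kind of change, so the size of the step in this assay can only be guessed. Given that compound 1 already needs a high concentration at 28000 nM, the expectation for compound 4 is a step of a 1.6-fold higher number from compound 1 to compound 4 (0.21 log units; within the scatter), towards needing somewhat more compound, with a real chance that the result lands beyond what the assay can resolve. Compound 4 is therefore estimated at 45000 nM, within a range from 9000 nM to 200000 nM.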

Compound 4, half-maximal effective concentration: 9300 nM
Estimate against measurement, compound 4: 4.8-fold (0.68 log units) above; the measured number falls inside the stated range.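

Among the compounds shown here, the change gives the first step that can be read in this assay: a 3.0-fold lower number from compound 1 to compound 4 (0.48 log units; beyond the scatter), with 2-methoxyethoxy in place of thiophen-2-yl on a carbonyl carbon. In this pair, the aromatic ring is not needed at this position for the effect, since an open chain with no ring and the same count of heavy atoms moves the number towards less compound being needed. The earlier compounds could not show this, because no step could be read among them: the limit of > 100000 nM in this assay, at which 2 of the 4 values shown sit.

This single pair cannot separate the loss of the ring from the gain of the ester, and it cannot show whether the size of the step depends on the length of the chain or on the oxygen atoms within it. As far as these compounds go, whether an ethoxy group, a longer chain ending in an amine, or a carboxylic acid on the same carbonyl carbon would move the number further, and in which direction, stays open.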